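The source may report more compounds than this note shows. Statements on the series, on what has been measured and on what is new or still open speak of the compounds shown alone.

In a functional assay on SK-OV-3 cells (Homo sapiens) for cytotoxicity (a higher number here means a weaker inhibitor, a lower number a stronger inhibitor), two compounds built on one shared core have been measured so far. Compound 1 (`C=C/C=C\[C@H](C)[C@H](OC(N)=O)[C@@H](C)[C@H](O)[C@@H](C)C/C(C)=C\[C@H](C)[C@@H](O)[C@@H](C)/C=C\CCc1cccc(O)c1C`) gives 270 nM, and compound 2 (`C=C/C=C\[C@H](C)[C@H](OC(N)=O)[C@@H](C)[C@H](O)[C@@H](C)C/C(C)=C\[C@H](C)[C@@H](O)[C@@H](C)/C=C\CCc1cccc(OC)c1`) gives 370 nM. These two values lie within the scatter of each other, so compound 2 holds no separate rank on these numbers.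

Compound 3 (`C=C/C=C\[C@H](C)[C@H](OC(N)=O)[C@@H](C)[C@H](O)[C@@H](C)C/C(C)=C\[C@H](C)[C@@H](O)[C@@H](C)/C=C\CCc1cc(O)cc(O)c1`) keeps the shared core and alters a single group: 3,5-dihydroxyphenyl in place of 3-methoxyphenyl on a saturated chain carbon, two bonds along the chain from a double-bonded chain carbon. The new group sits on a saturated chain carbon, two bonds along the chain from a double-bonded chain carbon. Among the measured compounds shown here, one measured step bears on this change: a 1.4-fold higher number from compound 1 to compound 2 (0.14 log units; within the scatter). That step exchanged the group at the same place, and its size stayed within the scatter. For the measured compounds named here, it is a single step, however, and no measured compound carries the 3,5-dihydroxyphenyl group. The expectation is therefore for no step beyond the scatter in this assay, with no firm direction and a wide margin. The expected step is a 1.2-fold higher number from compound 2 to compound 3 (0.09 log units; within the scatter). For compound 3 the estimated value is 450 nM, with an expected range of 170 nM to 1300 nM.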

Compound 3, half-maximal inhibitory concentration: 40 nM
Beside the measured number, compound 3's estimate is 11-fold (1.05 log units) above it; measured number below the stated range.
By their numbers in this assay, from the lowest: compound 3; then compounds 1 and 2 (each within the scatter of the next).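

In this assay, the saturated chain carbon two bonds along the chain from a double-bonded chain carbon proves sensitive to the group it carries: 3,5-dihydroxyphenyl in place of 3-methoxyphenyl gives a 9.3-fold lower number from compound 2 to compound 3 (0.97 log units; beyond the scatter), and 3,5-dihydroxyphenyl in place of 3-hydroxy-2-methylphenyl gives a 6.8-fold lower number from compound 1 to compound 3 (0.83 log units; beyond the scatter). Among the compounds shown here, the earlier exchange at this place had stayed within the scatter, so compound 3 is the first to show that a change here can move the number beyond it, and with both of its steps beyond the scatter, compound 3 is the strongest inhibitor of the three. No available evidence accounts for this difference.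

The compounds shown do not tell whether both hydroxyl groups of the 3,5-dihydroxyphenyl group are needed, since neither 3-hydroxyphenyl nor 3,5-dimethoxyphenyl stands among them. They also leave open how this position would respond to a ring bearing other groups, such as 3,5-diaminophenyl or 3,5-difluorophenyl, and whether the step seen in this one cell assay would hold elsewhere.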